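Amide variation on the shared core: compound 2 to compound 4

The source may hold more compounds than are shown below. What is called first, only, known or untested is meant among the compounds shown, and "the series" means these compounds.

Compound 1 `CNC(=O)CC1CCc2cc(OC)c(OC)cc21`, compound 2 `CCN(CC)C(=O)CC1CCc2cc(OC)c(OC)cc21` and compound 3 `COc1cc2c(cc1OC)C(CC(=O)NC1CCCCC1)CC2` share one core and differ only at the amide. In a functional assay on the whole organism (strain Wistar) for inhibition, with Rattus norvegicus as the target, read by paw edema, with stated times of 60 min and 24 h, at a dose of 100 mg/kg by the oral route (a lower number here means less inhibition, a higher number more inhibition at the dose given (going by the name of the read-out)), compound 1 gives 33.3%, compound 2 gives 16.7% and compound 3 gives 53.3%. Compound 2 stands lowest of the three; its nearest neighbour is compound 1 and its furthest is compound 3, as seen in a number 16.6 percentage points lower from compound 1 to compound 2 (beyond the scatter) and in a number 36.6 percentage points higher from compound 2 to compound 3 (beyond the scatter). Between the two secondary amides the read-out moved a number 20 percentage points higher from compound 1 to compound 3 (beyond the scatter). Compound 4 `COc1cc2c(cc1OC)C(CC(=O)N1CCOCC1)CC2` is the next member; relative to compound 2 the change is morpholin-4-yl in place of diethylamino on a carbonyl carbon. Both steps touching compound 2 bear on it: the step of a number 16.6 percentage points lower from compound 1 to compound 2 (beyond the scatter) brought in diethylamino and lowered the number, the step of a number 36.6 percentage points higher from compound 2 to compound 3 (beyond the scatter) removed it and raised the number strongly. The entering morpholin-4-yl, like the leaving diethylamino, brings 0 hydrogen-bond donors, so no large rise is expected in this assay. The expected step is small and upward, a number 7.3 percentage points higher from compound 2 to compound 4 (within the scatter). Compound 4 is estimated at 24% in this assay, within 8% to 42%.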

Compound 4, a percentage reported as inhibition, in the whole organism at one dose (the size of the read-out at that dose, not a potency): 23.3%
Compound 4: the middle estimate sits 0.7 percentage points above what was measured; low and high end bracket the measured number.
By their numbers in this assay, from the lowest: compounds 2, 4 and 1 (each within the scatter of the next, the first and the last beyond it); then compound 3.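

On the carbonyl carbon, morpholin-4-yl cannot be told apart from diethylamino, with a number 6.6 percentage points higher from compound 2 to compound 4 (within the scatter) in this assay, and it also cannot be told apart from methylamino, with a number 10 percentage points lower from compound 1 to compound 4 (within the scatter), even though compound 1 and compound 2 lie beyond the scatter of each other. Cyclohexylamino does stand apart, with a number 30 percentage points lower from compound 3 to compound 4 (beyond the scatter), so both amides without an amide hydrogen, compound 2 and compound 4, now fall beyond the scatter of compound 3, while compound 1 keeps the amide hydrogen and still stays within the scatter of compound 4, against any simple link to that hydrogen. No measurement available here accounts for these differences. The compounds shown leave open whether the ring in compound 4 matters apart from its oxygen, which a piperidin-1-yl amide would test. They also leave open whether the cyclohexyl result is specific to that ring, which a cyclopentylamino or benzylamino amide would address.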